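Chloro position on the benzoyl group of compound 3

The source may hold more compounds than are shown below. What is called first, only, known or untested is meant among the compounds shown, and "the series" means these compounds.

Among the compounds with values here, compound 3, `O=C(c1cccc(Cl)c1)N1CCn2nc(-c3ccccn3)cc2C1`, gives the lowest number of the three measured so far in a functional assay on HEK293 cells for negative allosteric modulation of metabotropic glutamate receptor 5 (Homo sapiens), read by calcium flux, with a stated time of 20 min (a lower number here means a stronger inhibitor, a higher number a weaker inhibitor), at 176 nM. Compound 1, `O=C(c1ccccc1)N1CCn2nc(-c3ccncc3)cc2C1`, gives 1290 nM in this assay, and compound 2, `O=C(c1ccccc1Cl)N1CCn2nc(-c3ccccn3)cc2C1`, gives 2480 nM. The one step measured so far within the shared core is a 14-fold lower number from compound 2 to compound 3 (1.15 log units; beyond the scatter), so moving the chlorine on the benzoyl group has already shown a large effect.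

Compound 4, `O=C(c1ccc(Cl)cc1)N1CCn2nc(-c3ccccn3)cc2C1`, differs from compound 3 only in that change: 4-chlorophenyl in place of 3-chlorophenyl on a carbonyl carbon. Within the data shown here, no measured pair covers this particular move, so the only bearing is the large step from compound 2 to compound 3, which shows that the position of the chlorine is not neutral in this assay. On that basis a step beyond the scatter is expected, more likely towards a higher number, as a 2.6-fold higher number from compound 3 to compound 4 (0.41 log units; beyond the scatter). Compound 4 is therefore estimated at 450 nM in this assay, with a range from 120 nM to 1800 nM.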

Compound 4, half-maximal inhibitory concentration: 9470 nM
Compound 4: middle estimate off by 21-fold (1.32 log units), on the low side; the whole stated range lies below it.
By their numbers in this assay, from the lowest: compound 3; then compounds 1 and 2 (each within the scatter of the next); then compound 4.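

The 4-chlorophenyl group proves far worse than 3-chlorophenyl in this assay, with a 54-fold higher number from compound 3 to compound 4 (1.73 log units; beyond the scatter) on the shared core. It also falls behind 2-chlorophenyl, with a 3.8-fold higher number from compound 2 to compound 4 (0.58 log units; beyond the scatter) in this comparison, so the 2-chlorophenyl compound no longer marks the high end of the chlorine series. With all three chlorophenyl isomers in hand, compound 3 has the lowest number and compound 4 the highest, and each step among the three lies beyond the scatter, which the earlier pair alone could not show.

Nothing available accounts for this order of the isomers.

Still open, from the compounds shown here alone, is whether the same order holds for a methoxy or a fluoro group at these places on the phenyl ring. Also open, going by these compounds, is how an unsubstituted phenyl on the core of compound 3 compares with the three chlorinated compounds.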